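Methyl on the Pyrazole Carbon of a Ketone Inhibitor

The source may hold more compounds than are shown below. What is called first, only, known or untested is meant among the compounds shown, and "the series" means these compounds.

Compound 1 `N#Cc1cnn(C(=O)NCCCCc2ccccc2)c1` — 42 nM
Compound 2 `Cc1cnn(C(=O)OCCCCc2ccccc2)c1` — > 5000 nM
Compound 3 `O=C(CCCCCc1ccccc1)n1cccn1` — > 5000 nM

Three compounds were measured in an assay on isolated protein for inhibition of Fatty-acid amide hydrolase 1 (Rattus norvegicus), with a stated time of 3 h; a lower number here means a stronger inhibitor, a higher number a weaker inhibitor. Compound 1 gives 42 nM. For compound 2 this assay reports only a limit, > 5000 nM. For compound 3 it likewise reports only a limit, > 5000 nM. Compound 3 thus stands at the limit of > 5000 nM in this assay, at which 2 of the 3 values shown sit, with no number of its own; only compound 1 has a value inside the measurable range.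

Compound 4 `Cc1cnn(C(=O)CCCCCc2ccccc2)c1` differs from compound 3 in one place: methyl in place of hydrogen on an aromatic carbon. For the measured compounds named here, no step between two measured compounds is available to calibrate this change. Compound 2 also carries the methyl group, but its linker differs from that of compound 3, so the two do not form a single-change pair. The step from compound 3 to compound 4 is therefore expected to be small, in no particular direction, and probably within the scatter, which means a step that the limit leaves unreadable from compound 3 to compound 4. Compound 4 is expected to give about 6000 nM, between 1500 nM and 25000 nM, with a good chance that this assay again reports only a limit.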

Compound 4, inhibition constant: > 5000 nM
Compound 4 gave a limit, no number (the forecaster's own chance of this, stated with the estimate: 65%); the middle value does not contradict the limit.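

Compound 3 and compound 4 both stand only as limits in this assay, so no step can be read from compound 3 to compound 4. The compounds shown leave open whether methyl in place of hydrogen on an aromatic carbon changes the inhibition at all.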